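Urea replacement of benzylamine in the sulfonyl series

The source may hold more compounds than are shown below. What is called first, only, known or untested is meant among the compounds shown, and "the series" means these compounds.

Of the compounds shown here, three sharing the same core have been measured in a functional assay on MKN-45 cells (Homo sapiens) for cytotoxicity; on this read-out lower numbers stand for stronger inhibition and higher numbers for weaker inhibition. Compound 1 `COc1ccc(S(=O)(=O)N2CCc3cccc(NS(=O)(=O)c4ccc([N+](=O)[O-])cc4)c32)cc1` gives 933 nM in this assay. Compound 2 `COc1ccc(S(=O)(=O)N2CCc3cc(Br)cc(NC(=O)c4ccncc4)c32)cc1` gives 86 nM. Compound 3 `COc1ccc(S(=O)(=O)N2CCc3cccc(NCc4ccccc4)c32)cc1` returns only a limit, > 10000 nM, so no number is known for it; this is the limit of > 10000 nM in this assay, at which 1 of the 3 values shown sits. Compound 3 therefore stands at the weak end of the numbers shown, while compound 2 carries the smallest value among the three, with compound 1 in between.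

The next compound, compound 4 `COc1ccc(S(=O)(=O)N2CCc3cccc(NC(=O)N(C)c4ccccc4)c32)cc1`, differs from compound 3 in one place: methyl(phenyl)carbamoyl in place of benzyl on a nitrogen on an aromatic ring. Going by the values given here, no measured pair separated by a single change exists in the set, so no computed step can be drawn on. What the values show is that compound 2 and compound 1, both with a linker that carries a carbonyl or sulfonyl, return numbers, whereas compound 3, with the benzyl group, returns only a limit.

From this, compound 4 is expected to move into the measurable range, with the step from compound 3 to compound 4 estimated as an at least 5.0-fold lower number from compound 3 to compound 4 (0.69 log units; beyond the scatter) in this assay, though the chance of another limit is real. The estimate for compound 4 is 2000 nM, within 400 nM to 10000 nM.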

Compound 4, half-maximal inhibitory concentration: > 10000 nM
Compound 4 ended at the assay's limit (the forecaster's own chance of this, stated with the estimate: 30%); at least 5.0-fold (0.69 log units) between middle value and limit.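

In this assay, compound 3 and compound 4 both end at a limit of the assay rather than at a number, so no step can be read between them: the limit of > 10000 nM in this assay, at which 2 of the 4 values shown sit.

The compounds shown leave open whether methyl(phenyl)carbamoyl in place of benzyl on a nitrogen on an aromatic ring changes the read-out at all.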